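From a 3-carboxypropyl chain to a pyrrolidin-3-yl ring

The compounds below may be only part of what the source reports. "The series", "measured", "known", "first", "only" and "open" are said of these compounds alone.

In a physicochemical assay for solubility (on this read-out higher numbers stand for higher solubility and lower numbers for lower solubility), compound 3 (`O=C(O)CCCC(=O)N1CCC(NS(=O)(=O)c2cc(S(=O)(=O)c3ccccc3)ccc2C(F)(F)F)CC1`) gives 50000 nM and is level at the top of the three numbers with compound 2 (`CN(C)c1ccc(C(=O)N2CCC(NS(=O)(=O)c3cc(S(=O)(=O)c4ccccc4)ccc3C(F)(F)F)CC2)cc1`) at 50000 nM while compound 1 (`O=C(c1ccccc1)N1CCC(NS(=O)(=O)c2cc(S(=O)(=O)c3ccccc3)ccc2C(F)(F)F)CC1`) sits lowest at 12500 nM on the same scale. Compound 4 (`O=C([C@H]1CCNC1)N1CCC(NS(=O)(=O)c2cc(S(=O)(=O)c3ccccc3)ccc2C(F)(F)F)CC1`) carries pyrrolidin-3-yl in place of 3-carboxypropyl on a carbonyl carbon. Within the data shown here, three measured steps bear on this: two modest rises, a 4.0-fold higher number from compound 1 to compound 2 (0.60 log units; beyond the scatter) and a 4.0-fold higher number from compound 1 to compound 3 (0.60 log units; beyond the scatter) and then no change at the digits printed from compound 2 to compound 3 (within the scatter) for a swap on that same carbonyl carbon. Among the measured compounds shown here, no measured compound carries pyrrolidin-3-yl, so the expectation stays cautious. The expected outcome is no change at the digits printed from compound 3 to compound 4 (within the scatter) with no shift beyond the scatter. Compound 4 is estimated at 50000 nM (range 20000 nM to 100000 nM).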

Compound 4, solubility: 25000 nM
Compound 4: the middle estimate sits 2.0-fold (0.30 log units) above what was measured; measured number inside the range.
By their numbers in this assay, from the lowest: compounds 1, 4, 2 and 3 (each within the scatter of the next, the first and the last beyond it).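

In this assay the pyrrolidin-3-yl ring on the carbonyl carbon gives three steps that all stay within the scatter (a 2.0-fold lower number from compound 3 to compound 4 (0.30 log units; within the scatter); a 2.0-fold lower number from compound 2 to compound 4 (0.30 log units; within the scatter); a 2.0-fold higher number from compound 1 to compound 4 (0.30 log units; within the scatter)). Among these compounds, compound 4 therefore cannot be told apart from any of the earlier compounds, even though compound 1 and compound 3 lie beyond the scatter of each other. Nothing measured here explains this result. Still open, on these data alone, is how the opposite stereocentre of pyrrolidin-3-yl, a piperidine ring or an open chain ending in an amine would read at this carbonyl carbon.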